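The compounds below may be only part of what the source reports. "The series", "measured", "known", "first", "only" and "open" are said of these compounds alone.

Working notes on the series. Compound 1 `NCCCCN(C[C@H]1Cc2nccnc2CN1)[C@H]1CCCc2cccnc21` and compound 2 `NC(=O)NCCCCN(C[C@H]1Cc2ncccc2CN1)[C@H]1CCCc2cccnc21` share one core and differ from each other in one place. In an ADME assay for permeability, using PAMPA, with a stated time of 4 h, at pH 7.4 (on this read-out higher numbers stand for higher permeability and lower numbers for lower permeability), compound 1 gives 2 nm/s. In this assay compound 2 gives 2 nm/s; compound 2 stands level with compound 1 at the digits shown, the two values lying within the scatter of each other, so no order between them is drawn. Among the measured compounds shown here, no step between the two measured compounds is recorded.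

Compound 3 `CN(CCCCN(C[C@H]1Cc2ncccc2CN1)[C@H]1CCCc2cccnc21)C1CCOCC1` has not yet been measured in this assay. It differs from compound 2 in one place: methyl(oxan-4-yl)amino in place of ureido on a saturated chain carbon, four bonds along the chain from an amine nitrogen. Nothing measured here shows how a change of this kind moves the read-out, so any expectation rests on compound 2 at 2 nm/s alone. In this assay the step from compound 2 to compound 3 is expected to be a 4.0-fold higher number from compound 2 to compound 3 (0.60 log units; beyond the scatter), a modest rise that may not exceed the scatter. Compound 3 is accordingly estimated at 8 nm/s, within a range of 2 nm/s to 40 nm/s.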

Compound 3, apparent permeability: 490 nm/s
The estimate for compound 3 lay 61-fold (1.79 log units) below the measured number; measured number outside the range, above it.
By their numbers in this assay, from the lowest: compounds 1 and 2 (each within the scatter of the next); then compound 3.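

In this assay, the position on a saturated chain carbon, four bonds along the chain from an amine nitrogen, proves able to move the read-out strongly: methyl(oxan-4-yl)amino in place of ureido gives a 250-fold higher number from compound 2 to compound 3 (2.39 log units; beyond the scatter). The change alters several counted features at once: ureido, with no ring and 2 hydrogen-bond donors, gives way to a group with one six-membered non-aromatic ring and 0 hydrogen-bond donors, and neither group carries a net charge. No available measurement bears on which of these differences accounts for the step.

The compounds shown leave open whether the step follows the loss of ureido or the presence of methyl(oxan-4-yl)amino. Dimethylamino, acetamido or a methyl(cyclohexyl)amino group at this place would help to separate those two readings.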